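Swapping the aryl group on a weak aortic inhibitor series

This account rests on a few compounds, and the source may have more. Where it says the series, first, only, none or still open, it means among the compounds named here.

Of the compounds shown here, three have been measured so far, all built on the same core and all weak inhibitors. Compound 1 `CCOc1nc(-c2cc3ccccc3o2)cc(-c2ccc3ccccc3c2)c1C#N` gives 423000 nM in a functional assay on aorta (strain Wistar) for inhibition, with Thoracic aorta (Rattus norvegicus) as the target; a higher number here means a weaker inhibitor, a lower number a stronger inhibitor. Compound 2 `COc1nc(-c2cc3ccccc3o2)cc(-c2ccc(Cl)cc2Cl)c1C#N` gives 322000 nM in this assay. Compound 3 `CCOc1nc(-c2cc3ccccc3o2)cc(-c2ccc(Cl)cc2Cl)c1C#N` gives 442000 nM in this assay, the highest of the three numbers, although its gap to the others is within the scatter: the step of a 1.0-fold higher number from compound 1 to compound 3 (0.02 log units; within the scatter) and the step of a 1.4-fold higher number from compound 2 to compound 3 (0.14 log units; within the scatter) are both too small to count as real differences.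

The unmeasured compound 4 `CCOc1nc(-c2cc3ccccc3o2)cc(-c2ccc(C)cc2)c1C#N` differs from compound 3 in one place: 4-methylphenyl in place of 2,4-dichlorophenyl on an aromatic carbon. Within the data shown here, the measured step that bears most directly on this is the one from compound 1 to compound 3, where one aryl group was exchanged for another at the same place and the number barely moved, as a 1.0-fold higher number from compound 1 to compound 3 (0.02 log units; within the scatter) shows. The step of a 1.4-fold higher number from compound 2 to compound 3 (0.14 log units; within the scatter) concerns a different place and was also within the scatter. Among the measured compounds shown here, nothing among the measured compounds points to a change beyond the scatter when the aryl group is exchanged again, so compound 4 is expected to land close to compound 3, with an expected step of a 1.1-fold lower number from compound 3 to compound 4 (0.02 log units; within the scatter). The estimate for compound 4 in this assay is 420000 nM, within a range from 200000 nM to 900000 nM.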

Compound 4, half-maximal inhibitory concentration: 290000 nM
For compound 4 the middle estimate is 1.4-fold (0.16 log units) above the measured one; measured number inside the range.
By their numbers in this assay, from the lowest: compounds 4, 2, 1 and 3 (each within the scatter of the next).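

At the aromatic carbon opposite the ring nitrogen, 4-methylphenyl in place of 2,4-dichlorophenyl gives a 1.5-fold lower number from compound 3 to compound 4 (0.18 log units; within the scatter), and 4-methylphenyl in place of naphthalen-2-yl gives a 1.5-fold lower number from compound 1 to compound 4 (0.16 log units; within the scatter). Together with the earlier aryl exchange, this places three different carbon-only aromatic groups within the scatter of one another in this assay, so this position has now been tested with a group that carries methyl and no chlorine, and no real difference has appeared. No measurement shown here offers an explanation for how closely these numbers agree.

From the compounds shown here alone, every group tested at this position is a hydrocarbon or chlorinated aromatic group, so it remains open whether a phenyl ring carrying an amine or a carboxylic acid would move the number beyond the scatter. The exchange of ethoxy for methoxy has been read only with 2,4-dichlorophenyl in place, which leaves open how a longer chain at that oxygen would behave and whether either change would hold with 4-methylphenyl on the core.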